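Lengthening the imidazole tether on an inactive series

The source may report more compounds than this note shows. Statements on the series, on what has been measured and on what is new or still open speak of the compounds shown alone.

Measured compounds:
Compound 1, `Cn1cc(C2=C(c3nn(CCn4ccnc4)c4ncccc34)C(=O)NC2=O)c2ccccc21`: in a functional assay on K562 cells (Homo sapiens) for antiproliferative activity, read by MTT assay, with a stated time of 48 h (on this read-out higher numbers stand for weaker inhibition and lower numbers for stronger inhibition), compound 1 gives only a limit of the assay, > 100000 nM.
Compound 2, `Cn1cc(C2=C(c3n[nH]c4ncccc34)C(=O)N(c3cccc4ccccc34)C2=O)c2ccccc21`: in this assay compound 2 gives only a limit, > 100000 nM.
Compound 3, `COc1ccc(N2C(=O)C(c3cn(C)c4ccccc34)=C(c3nn(CCCN4CCCCC4)c4ncccc34)C2=O)cc1`: in this assay compound 3 gives only a limit, > 100000 nM.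

Compound 1 stands nowhere in particular among these numbers: none of the three compounds returns a measured value, and all three sit at the same limit, as the limit of > 100000 nM in this assay, at which 3 of the 3 values shown sit, records. For the measured compounds named here, there is therefore no measured step between any two of them to learn from, and nothing to separate compound 1 from compound 2 or compound 3.

The unmeasured compound 4, `Cn1cc(C2=C(c3nn(CCCn4ccnc4)c4ncccc34)C(=O)NC2=O)c2ccccc21`, differs from compound 1 by a single change: (1H-imidazol-1-yl)methyl in place of 1H-imidazol-1-yl on a saturated chain carbon, two bonds along the chain from an aromatic nitrogen. The chain that carries the imidazole grows by one carbon, with no change in ring count, donors or acceptors.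

With every neighbour at the limit, a change this small is not expected to move the read-out beyond the scatter; the expected step that the limit leaves unreadable from compound 1 to compound 4 is essentially none. Compound 4 is therefore estimated at 150000 nM, within a range of 50000 nM to 500000 nM, most likely reported again only as a limit.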

Compound 4, half-maximal inhibitory concentration: 13800 nM
Estimate against measurement, compound 4: 11-fold (1.04 log units) above; measured number outside the range, below it.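

In this assay, the length of the chain carrying the imidazole proves to matter: replacing 1H-imidazol-1-yl with (1H-imidazol-1-yl)methyl on this saturated chain carbon gives an at least 7.2-fold lower number from compound 1 to compound 4 (0.86 log units; beyond the scatter). The change adds one carbon and leaves the counted rings, hydrogen-bond donors and hydrogen-bond acceptors the same, so a small extension at this position is enough to produce a difference beyond the scatter. Compound 4 also gives the series its first measured number rather than a limit, which makes this chain a place where further changes could be compared: the limit of > 100000 nM in this assay, at which 3 of the 4 values shown sit.

On these data alone, whether a longer chain, such as a four-carbon tether ending in the same imidazole, would lower the number further remains open. So does whether the imidazole itself is needed at the end of the 3-(1H-imidazol-1-yl)propyl chain, or whether a morpholine or a dimethylamino group there would serve as well.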